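Trimming an ethyl to a methyl on an aromatic ring

This account rests on a few compounds, and the source may have more. Where it says the series, first, only, none or still open, it means among the compounds named here.

Measured compounds:
- compound 1, `CCc1ccc(-c2nn3cc(-c4cccc(N)c4)nc3s2)cc1`: 22000 nM
- compound 2, `COc1cccc(Cc2nn3cc(-c4cccc(N)c4)nc3s2)c1`: 40000 nM
- compound 3, `C=C(Br)C(=O)Nc1cccc(-c2cn3nc(-c4ccccc4)sc3n2)c1`: 960 nM

In a functional assay on CCRF-CEM cells (Homo sapiens) for inhibition, read by cell counting, with a stated time of 3 days (on this read-out higher numbers stand for weaker inhibition and lower numbers for stronger inhibition), compound 1 gives 22000 nM, the second highest of the three numbers. Compound 2 sits within the scatter of it, so nothing separates them. Compound 3 gives 960 nM, a far lower number, well beyond the scatter.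

Compound 4, `Cc1ccc(-c2nn3cc(-c4cccc(N)c4)nc3s2)cc1`, is not yet measured. It differs from compound 1 by hydrogen in place of methyl on a saturated chain carbon bound to an aromatic carbon. Such a loss of a single carbon from a chain usually moves the number little, so the step of a 1.1-fold higher number from compound 1 to compound 4 (0.06 log units; within the scatter) is expected to stay within the scatter. Compound 4 is therefore estimated at 25000 nM, somewhere between 8000 nM and 80000 nM.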

Compound 4, half-maximal inhibitory concentration: 5900 nM
For compound 4 the middle estimate is 4.2-fold (0.63 log units) above the measured one; measured number below the stated range.
By their numbers in this assay, from the lowest: compound 3; then compound 4; then compounds 1 and 2 (each within the scatter of the next).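

Within the data shown here, this is the first pair that differs in only one place, and in this assay the change of ethyl to methyl gives a 3.7-fold lower number from compound 1 to compound 4 (0.57 log units; beyond the scatter). Removing a single carbon from the chain is therefore enough to shift the number at this place on compound 1. No measurement available here explains the shift.

Two compounds cannot show whether shortening the chain further, to a bare hydrogen on the ring, would continue this direction. Nor can they show how a longer chain such as propyl would behave.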